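The source may hold more compounds than are shown below. What is called first, only, known or untested is meant among the compounds shown, and "the series" means these compounds.

Measured so far in a functional assay on HT-29 cells (Homo sapiens) for antiproliferative activity, with a stated time of 48 h; a lower number here means a stronger inhibitor, a higher number a weaker inhibitor:
- compound 1, `CCCCC(OC)c1cccc(NC(=O)NCCCCl)c1`: 56000 nM
- compound 2, `CCCCC(OC)c1cccc(NC(=O)NC(=O)CC)c1`: here the assay reports only a limit, > 100000 nM
- compound 3, `CCCCC(OC)c1cccc(NC(=O)CCCCl)c1`: here too the assay reports only a limit, > 100000 nM

Compound 3 therefore has no number of its own in this assay, only a limit, and it shares that limit with one other compound, as the limit of > 100000 nM in this assay, at which 2 of the 3 values shown sit, shows. Among the three, only compound 1 gives an actual number.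

The unmeasured compound 4, `C=CC(=O)Nc1cccc(C(CCCC)OC)c1`, differs from compound 3 in one place: vinyl in place of 3-chloropropyl on a carbonyl carbon. The carbonyl carbon and the amide-type nitrogen beside it stay; only the chain on that carbonyl carbon is changed.

Going by the values given here, none of the measured steps makes this same exchange. The steps that touch compound 3 are an at least 1.7-fold higher number from compound 1 to compound 3 (0.25 log units; that floor lies within the scatter) and a step that the two limits leave unreadable from compound 2 to compound 3, and the remaining one is an at least 1.7-fold higher number from compound 1 to compound 2 (0.25 log units; that floor lies within the scatter). Each of them runs into a limit, so none tells how a vinyl group compares with a 3-chloropropyl group on this carbonyl carbon. The expectation for compound 4 therefore rests on a starting point that is itself only a limit, and a wide range is the honest answer.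

Compound 4 is expected to give 30000 nM, with a range from 5000 nM to 200000 nM. This estimate means an expected step of an at least 3.3-fold lower number from compound 3 to compound 4 (0.52 log units; beyond the scatter).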

Compound 4, half-maximal inhibitory concentration: 40000 nM
Estimate against measurement, compound 4: 1.3-fold (0.12 log units) below; the measured number falls inside the stated range.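

In this assay, vinyl in place of 3-chloropropyl on the carbonyl carbon gives an at least 2.5-fold lower number from compound 3 to compound 4 (0.39 log units; beyond the scatter), which shows that this position can yield a measurable number without the (3-chloropropyl)amino group of compound 1. Vinyl in place of propanoylamino on the same carbon gives an at least 2.5-fold lower number from compound 2 to compound 4 (0.39 log units; beyond the scatter), so vinyl also compares favourably with the second group that had reached no measurable number. Against (3-chloropropyl)amino, the only other group here with a real number, vinyl gives a 1.4-fold lower number from compound 1 to compound 4 (0.15 log units; within the scatter), so these two groups cannot be told apart, while the first two steps give only minimum sizes, as each starts from a limit: the limit of > 100000 nM in this assay, at which 2 of the 4 values shown sit.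

The compounds shown do not separate the effect of the double bond from that of the shorter chain, a question that an ethyl group on this carbonyl carbon would help to answer. They also leave open how a longer chain ending in an amine or a carboxylic acid at this position would read in this assay.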